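Fluoro in place of methyl on compound 2

This account rests on a few compounds, and the source may have more. Where it says the series, first, only, none or still open, it means among the compounds named here.

In a functional assay on HL-60 cells (Homo sapiens) for cytotoxicity, read by MTT assay, with a stated time of 72 h (on this read-out lower numbers stand for stronger inhibition and higher numbers for weaker inhibition), compound 1 `COc1cc(Nc2nc3ccccc3nc2S(=O)(=O)c2ccc(C)cc2)cc(OC)c1` gives 20 nM, compound 3 `Cc1ccc(S(=O)(=O)c2nc3ccccc3nc2Nc2cccc(O)c2)cc1` gives 400 nM and compound 2 `Cc1ccc(S(=O)(=O)c2nc3ccccc3nc2Nc2cccc(N)c2)cc1` gives 1080 nM. Compound 2 therefore carries the highest number of the three, and its steps to both others lie beyond the scatter. For the measured compounds named here, all the measured steps concern the group on the nitrogen. Replacing 3,5-dimethoxyphenyl with 3-aminophenyl gives a large step, a 54-fold higher number from compound 1 to compound 2 (1.73 log units; beyond the scatter), and replacing it with 3-hydroxyphenyl gives another large one, a 20-fold higher number from compound 1 to compound 3 (1.30 log units; beyond the scatter). Hydroxy in place of amino gives a modest step, a 2.7-fold lower number from compound 2 to compound 3 (0.43 log units; beyond the scatter).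

Compound 4 `Nc1cccc(Nc2nc3ccccc3nc2S(=O)(=O)c2ccc(F)cc2)c1` keeps the 3-aminophenyl group of compound 2 and changes elsewhere: fluoro in place of methyl on an aromatic carbon. This is fluoro in place of methyl on an aromatic carbon, para to a large group, so 4-methylphenyl becomes 4-fluorophenyl. None of the three measured steps touches this place, so they give no direct measure of the change. They show only how far the number moves when the group on the nitrogen changes, and that group stays the same here. With no evidence for a shift in either direction, no step beyond the scatter is expected, and the expected change is a 1.2-fold lower number from compound 2 to compound 4 (0.08 log units; within the scatter). For compound 4 the estimate is 900 nM, with an expected range from 350 nM to 2300 nM.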

Compound 4, half-maximal inhibitory concentration: 4040 nM
Compound 4: the middle estimate sits 4.5-fold (0.65 log units) below what was measured; the measured number lies above the stated range.
By their numbers in this assay, from the lowest: compound 1; then compound 3; then compound 2; then compound 4.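

For the compounds shown here, the place on the 4-methylphenyl group, which no earlier step touched, is not silent: in this assay, fluoro in place of methyl on an aromatic carbon gives a 3.7-fold higher number from compound 2 to compound 4 (0.57 log units; beyond the scatter). The number therefore depends on this ring as well as on the group on the nitrogen, although this modest step, like a 2.7-fold lower number from compound 2 to compound 3 (0.43 log units; beyond the scatter), is much smaller than the large 54-fold higher number from compound 1 to compound 2 (1.73 log units; beyond the scatter). The change of a single heavy atom, with no hydrogen-bond donor or acceptor counted on either side, moves the number beyond the scatter, but nothing measured here bears on what lies behind that shift.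

The compounds shown leave open whether 4-fluorophenyl in place of 4-methylphenyl would move the number in the same direction and by a similar amount with 3,5-dimethoxyphenyl or 3-hydroxyphenyl on the nitrogen, as in compound 1 and compound 3. Going by these compounds alone, they also leave open how chloro, methoxy or a plain hydrogen at this place would compare with methyl and fluoro, so the two groups seen here give only a single step and no trend.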